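From Ethyl to tert-Butyl on the Shared Core

The compounds below may be only part of what the source reports. "The series", "measured", "known", "first", "only" and "open" are said of these compounds alone.

Three close analogues share one core. Compound 1 `Cc1ccc(C)c(C(=O)/C=C/C(=O)O)c1` gives 5900 nM in a functional assay on K562 cells (Homo sapiens) for inhibition, read by MTT assay, with a stated time of 72 h; on this read-out higher numbers stand for weaker inhibition and lower numbers for stronger inhibition. Compound 2 `CCc1ccc(C(=O)/C=C/C(=O)O)cc1` gives 5530 nM in this assay, and compound 3 `Cc1ccc(C(=O)/C=C/C(=O)O)cc1C` gives 5620 nM. Compound 2 holds the lowest of the three numbers shown, but its gaps to compound 3 and to compound 1 both lie within the scatter, so the three stand level. Compound 4 `CC(C)(C)c1ccc(C(=O)/C=C/C(=O)O)cc1` has not yet been measured. It differs from compound 2 by tert-butyl in place of ethyl on an aromatic carbon. For the measured compounds named here, with no measured step of this kind to lean on, the author expects the step of a 1.2-fold lower number from compound 2 to compound 4 (0.06 log units; within the scatter) to stay within the scatter, or at most to be a small move toward stronger inhibition. Compound 4 is therefore estimated at 4800 nM, with a range of 2400 nM to 9600 nM.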

Compound 4, half-maximal inhibitory concentration: 4330 nM
For compound 4 the middle estimate is 1.1-fold (0.04 log units) above the measured one; measured number inside the range.
By their numbers in this assay, from the lowest: compounds 4, 2, 3 and 1 (each within the scatter of the next).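

In this assay the change of ethyl to tert-butyl on an aromatic carbon gives a 1.3-fold lower number from compound 2 to compound 4 (0.11 log units; within the scatter) and so stays level, which shows that this place, para to a group of 7 heavy atoms, accepts a branched group of 4 heavy atoms with no change beyond the scatter. The earlier compounds shown here offered no such step at this position. Nothing at hand bears on the reason for this result.

Open, from the compounds shown here alone, is whether an amine, a methoxy group or a longer chain at this aromatic carbon would move the number beyond the scatter.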